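The source may report more compounds than this note shows. Statements on the series, on what has been measured and on what is new or still open speak of the compounds shown alone.

Measured in a functional assay on PC-3 cells (Homo sapiens) for inhibition, read by sulforhodamine B assay, with a stated time of 72 h; a higher number here means a weaker inhibitor, a lower number a stronger inhibitor:
- compound 1 `Nc1sc(-c2ccc(Cl)cc2)c(-c2ccc(Cl)cc2)c1C(=O)N1CCCCC1=O`: 4940 nM
- compound 2 `CC(C)CNC(=O)c1c(N)sc(-c2ccc(Cl)cc2)c1-c1ccc(Cl)cc1`: 13200 nM
- compound 3 `CN1CCN(C(=O)c2c(N)sc(-c3ccc(Cl)cc3)c2-c2ccc(Cl)cc2)CC1`: 13100 nM

In this assay, compound 3 cannot be told apart from compound 2, as the comparison shows: a 1.0-fold lower number from compound 2 to compound 3 (0.00 log units; within the scatter). Compound 1 stands further off: a 2.7-fold higher number from compound 1 to compound 3 (0.42 log units; beyond the scatter), and likewise a 2.7-fold higher number from compound 1 to compound 2 (0.43 log units; beyond the scatter).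

Compound 4 `Nc1sc(-c2ccc(Cl)cc2)c(-c2ccc(Cl)cc2)c1C(=O)NC1CC1` keeps the shared core and differs from compound 3 only in the group on the carbonyl carbon: cyclopropylamino in place of 4-methylpiperazin-1-yl on a carbonyl carbon. In short, cyclopropylamino takes the place of 4-methylpiperazin-1-yl. The closest guide is compound 2, which carries isobutylamino at that carbonyl carbon and gives the flat step above, a 1.0-fold lower number from compound 2 to compound 3 (0.00 log units; within the scatter). The modest steps all involve compound 1, with its 2-oxopiperidin-1-yl group, which compound 4 does not carry. For the measured compounds named here, no measured compound carries cyclopropylamino itself, so the expectation rests on this one comparison, and no step beyond the scatter is expected.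

The expected step is a 1.2-fold lower number from compound 3 to compound 4 (0.08 log units; within the scatter).

For compound 4 the estimated value is 11000 nM, with an expected range from 5500 nM to 22000 nM.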

Compound 4, half-maximal inhibitory concentration: 3680 nM
The estimate for compound 4 lay 3.0-fold (0.48 log units) above the measured number, outside the stated range (below it).
By their numbers in this assay, from the lowest: compounds 4 and 1 (each within the scatter of the next); then compounds 3 and 2 (each within the scatter of the next).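

In this assay the group on the carbonyl carbon proves able to move the number among plain amides, as the change of isobutyl to cyclopropyl on an amide-type nitrogen gives a step beyond the scatter (a 3.6-fold lower number from compound 2 to compound 4 (0.55 log units; beyond the scatter)), which the flat pair of compound 2 and compound 3 had not suggested. The change from 4-methylpiperazin-1-yl to cyclopropylamino gives a step of the same size (a 3.6-fold lower number from compound 3 to compound 4 (0.55 log units; beyond the scatter)), while compound 4 cannot be told apart from compound 1 (a 1.3-fold lower number from compound 1 to compound 4 (0.13 log units; within the scatter)), so the lower numbers here no longer belong to the 2-oxopiperidin-1-yl group alone. Nothing available explains this result.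

Still open, on these data alone, is whether the cyclopropyl ring matters as a ring, which methylamino or cyclobutylamino on the carbonyl carbon would test. Also open, as far as these compounds go, is what a morpholin-4-yl group would give there.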